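Working notes: from compound 2 to compound 4

The source may hold more compounds than are shown below. What is called first, only, known or untested is meant among the compounds shown, and "the series" means these compounds.

In a functional assay on cells (Cancer cell lines, Homo sapiens) for inhibition, read by MTT assay, with a stated time of 48 h (on this read-out higher numbers stand for weaker inhibition and lower numbers for stronger inhibition), compound 2 `COc1ccc(/C=C/C(=O)NNC(=O)c2ccc3c(c2)OCCO3)cc1` gives 930 nM, the second highest of three numbers. Compound 1 `COc1cccc(/C=C/C(=O)NNC(=O)c2ccc3c(c2)OCCO3)c1` gives 170 nM and compound 3 `O=C(/C=C/c1ccc(F)cc1)NNC(=O)c1ccc2c(c1)OCCO2` gives 990 nM; compound 2 lies within the scatter of compound 3 and well above compound 1. Compound 4 `O=C(/C=C/c1cccc(Br)c1)NNC(=O)c1ccc2c(c1)OCCO2` differs from compound 2 by 3-bromophenyl in place of 4-methoxyphenyl on a double-bonded chain carbon bound to a double-bonded chain carbon. Among the compounds with values here, two measured steps bear on this change. The step of a 5.5-fold higher number from compound 1 to compound 2 (0.74 log units; beyond the scatter) shows that 4-methoxyphenyl in place of 3-methoxyphenyl raised the number beyond the scatter, while a 1.1-fold higher number from compound 2 to compound 3 (0.03 log units; within the scatter) shows that a halogen in place of methoxy on the aromatic carbon stayed within the scatter. Compound 4 carries a 3-substituted ring again, so a lower number is expected in this assay, roughly reversing the first step, a 3.7-fold lower number from compound 2 to compound 4 (0.57 log units; beyond the scatter). Compound 4 is therefore estimated at 250 nM, within 100 nM to 700 nM.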

Compound 4, half-maximal inhibitory concentration: 3330 nM
For compound 4 the middle estimate is 13-fold (1.12 log units) below the measured one, and the stated range ends below it.
By their numbers in this assay, from the lowest: compound 1; then compounds 2 and 3 (each within the scatter of the next); then compound 4.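

In this assay, a 3-substituted ring does not by itself give a low number at this position: 3-bromophenyl in place of 3-methoxyphenyl is a large step (a 20-fold higher number from compound 1 to compound 4 (1.29 log units; beyond the scatter)). 3-Bromophenyl also stands above both 4-substituted rings (a 3.6-fold higher number from compound 2 to compound 4 (0.55 log units; beyond the scatter) and a 3.4-fold higher number from compound 3 to compound 4 (0.53 log units; beyond the scatter)), so among these compounds the low number goes with 3-methoxyphenyl alone, not with the ring position as such. No measurement shown accounts for this change.

Open, as far as these compounds go, is what 3-ethoxyphenyl or 3-aminophenyl would give on this chain carbon, and whether a carboxylic acid there would keep the number of compound 1.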